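Piperidine amide in place of an acyclic amine chain

The source may hold more compounds than are shown below. What is called first, only, known or untested is meant among the compounds shown, and "the series" means these compounds.

Measured so far in a functional assay on CHO-K1 cells for antagonist activity at melanin-concentrating hormone receptor 1 (Homo sapiens), read by inositol phosphate accumulation, with stated times of 10 min and 45 min; on this read-out lower numbers stand for stronger inhibition and higher numbers for weaker inhibition:
compound 1 `Cc1nc(N2CCC(NS(=O)(=O)N(C)C)CC2)nc2ccc(NC(=O)/C=C/c3ccc(OC(F)(F)F)cc3)cc12`: 31 nM
compound 2 `Cc1nc(N2CCC(N3CCOC3=O)CC2)nc2ccc(NC(=O)/C=C/c3ccc(OC(F)(F)F)cc3)cc12`: 31 nM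
compound 3 `Cc1nc(NCCNC(=O)C2CC2)nc2ccc(NC(=O)/C=C/c3ccc(OC(F)(F)F)cc3)cc12`: 23 nM

Compound 3 gives the lowest of the three numbers, but both neighbours lie within the scatter of it: compound 1 and compound 2 sit close at the same distance. Within the shared core, two changes have been measured. The first, no change at the digits printed from compound 1 to compound 2 (within the scatter), swaps one substituent on the saturated ring for another and leaves the number unchanged. The second, a 1.3-fold lower number from compound 2 to compound 3 (0.13 log units; within the scatter), replaces the whole piperidinyl group by an open chain and again stays within the scatter.

Compound 4 `COCC(=O)NC1CCN(c2nc(C)c3cc(NC(=O)/C=C/c4ccc(OC(F)(F)F)cc4)ccc3n2)CC1` takes the step back toward the ring-bearing pattern of compound 1 and compound 2: 4-(((methoxymethyl)carbonyl)amino)piperidin-1-yl in place of (2-((cyclopropylcarbonyl)amino)ethyl)amino on an aromatic carbon. Both prior steps bear on this change, and neither moved the number beyond the scatter. Compound 4 is therefore expected to land near the three values already seen, with a 1.3-fold higher number from compound 3 to compound 4 (0.12 log units; within the scatter) as the expected step, and no direction beyond the scatter. The estimate for compound 4 in this assay is 30 nM, with a range from 12 nM to 75 nM.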

Compound 4, half-maximal inhibitory concentration: 14 nM
Estimate against measurement, compound 4: 2.1-fold (0.33 log units) above, within the range that was stated.
By their numbers in this assay, from the lowest: compounds 4, 3, 1 and 2 (each within the scatter of the next, the first and the last beyond it).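

Among the compounds that carry the piperidine ring in this assay, the group on its amine nitrogen is the first change to leave the scatter: ((methoxymethyl)carbonyl)amino in place of 2-oxo-1,3-oxazolidin-3-yl gives a 2.2-fold lower number from compound 2 to compound 4 (0.35 log units; beyond the scatter) on the saturated ring carbon, and (methoxymethyl)carbonyl in place of dimethylsulfamoyl gives a 2.2-fold lower number from compound 1 to compound 4 (0.35 log units; beyond the scatter) on the same nitrogen. The exchange of open chain for ring on the aromatic carbon between two ring nitrogen atoms reads differently, with a 1.6-fold lower number from compound 3 to compound 4 (0.22 log units; within the scatter) and so no separation of the 4-(((methoxymethyl)carbonyl)amino)piperidin-1-yl group from the (2-((cyclopropylcarbonyl)amino)ethyl)amino chain. Nothing among the data shown accounts for the modest steps on the piperidine.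

The compounds shown leave open whether those steps belong to the methoxymethyl part or to the amide itself, a question that a plain acetyl or a cyclopropylcarbonyl group on the same piperidine amine would address. Also open, as far as these compounds go, is how the (methoxymethyl)carbonyl group behaves on the open ethylamino chain, and whether a longer chain or a pyrrolidine ring at this aromatic carbon stays within the same range.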